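A larger aromatic group on the carbonyl carbon

The source may report more compounds than this note shows. Statements on the series, on what has been measured and on what is new or still open speak of the compounds shown alone.

Of the compounds shown here, three that share one core have been tested in an ADME assay on Vero cells (Chlorocebus sabaeus) for cytotoxicity, read by MTT assay, with a stated time of 48 h; on this read-out lower numbers stand for stronger inhibition and higher numbers for weaker inhibition. Compound 1 `O=c1cc(N2CCN(CC3CCC(NS(=O)(=O)c4ccccc4)CC3)CC2)sc2c([N+](=O)[O-])cc(C(F)(F)F)cc12` carries a (phenylsulfonyl)amino group on a saturated ring carbon; in this assay compound 1 reaches only the limit > 64 ug/mL. Compound 2 `Cc1ccc(C(=O)OC2CCC(CN3CCN(c4cc(=O)c5cc(C(F)(F)F)cc([N+](=O)[O-])c5s4)CC3)CC2)cc1` carries a ((4-methylphenyl)carbonyl)oxy group at the same place; in this assay compound 2 also reaches only the limit > 64 ug/mL. Compound 3 `CC(=O)NC1CCC(CN2CCN(c3cc(=O)c4cc(C(F)(F)F)cc([N+](=O)[O-])c4s3)CC2)CC1` carries an acetamido group there, and in this assay compound 3 reaches only the limit > 64 ug/mL. Because of the limit of > 64 ug/mL in this assay, at which 3 of the 3 values shown sit, none of the steps between them can be sized: the step from compound 1 to compound 2 is a step that the two limits leave unreadable from compound 1 to compound 2, the step from compound 1 to compound 3 is a step that the two limits leave unreadable from compound 1 to compound 3, and the step from compound 2 to compound 3 is a step that the two limits leave unreadable from compound 2 to compound 3.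

Compound 4 `O=C(OC1CCC(CN2CCN(c3cc(=O)c4cc(C(F)(F)F)cc([N+](=O)[O-])c4s3)CC2)CC1)c1ccc2ccccc2c1` is not yet measured. It differs from compound 2 only in that (naphthalen-2-yl in place of 4-methylphenyl on a carbonyl carbon). The measured steps that bear on this change are the two that leave compound 2, and both stayed at the limit, so no readable step in this assay is expected for compound 4. The expected step is therefore a step that the limit leaves unreadable from compound 2 to compound 4. In this assay compound 4 is estimated at 80 ug/mL, expected to fall between 40 ug/mL and 160 ug/mL.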

Compound 4, half-maximal inhibitory concentration: > 64 ug/mL
Compound 4 gave a limit, no number; the forecaster's own chance of this, stated with the estimate: 80%; the middle value is on the limit's open side.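

Compound 2 and compound 4 both give limits rather than numbers, so no step can be read for naphthalen-2-yl in place of 4-methylphenyl, because the values offer nothing to size: the limit of > 64 ug/mL in this assay, at which 4 of the 4 values shown sit.

Left open is whether any of these groups changes the result in this assay at all: the four compounds shown give no actual number to compare.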